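This account rests on a few compounds, and the source may have more. Where it says the series, first, only, none or still open, it means among the compounds named here.

Measured in a functional assay on MCF7 cells (Homo sapiens) for antiproliferative activity, read by MTT assay, with a stated time of 72 h; on this read-out lower numbers stand for stronger inhibition and higher numbers for weaker inhibition:
Compound 1 `CCN1CCN(c2cc(C)c3cc(NC(=O)c4cccnc4)ccc3n2)CC1`: 26600 nM
Compound 2 `CCN(CC)c1cc(C)c2cc(NC(=O)c3ccc(Cl)c(Cl)c3)ccc2n1`: > 50000 nM

Compound 2 gives no exact starting point: its > 50000 nM is a limit of this assay and not a number. The evidence so far is slim, namely (the limit of > 50000 nM in this assay, at which 1 of the 2 values shown sits).

Compound 3 `Cc1cc(N2CCN(C)CC2)nc2ccc(NC(=O)c3ccc(Cl)c(Cl)c3)cc12` differs from compound 2 in one place, where 4-methylpiperazin-1-yl stands in place of diethylamino on an aromatic carbon, next to the ring nitrogen: 4-methylpiperazin-1-yl in place of diethylamino on an aromatic carbon. For the measured compounds named here, no measured pair shows what this exchange does on its own. The nearest guide is compound 1, which also carries a piperazine ring at that place but has a different amide part, and which gives 26600 nM. On that single value, a modest step towards stronger inhibition in this assay is expected, although another result at the limit would be no surprise. The expected change is an at least 1.7-fold lower number from compound 2 to compound 3 (0.25 log units; that floor lies within the scatter). For compound 3, the estimated value is 28000 nM, with an expected range from 12000 nM to 60000 nM.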

Compound 3, half-maximal inhibitory concentration: 3000 nM
For compound 3 the middle estimate is 9.3-fold (0.97 log units) above the measured one; measured number outside the range, below it.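

In this assay, for the compounds shown here, the exchange of diethylamino for 4-methylpiperazin-1-yl on this aromatic carbon, next to the ring nitrogen, gives an at least 16-fold lower number from compound 2 to compound 3 (1.22 log units; beyond the scatter) and is the first one-place comparison, showing that the group at this position strongly shapes the read-out while the amide part stays the same. For compound 2 the printed > 50000 nM is a limit of the assay and not a number. The size of the step is therefore a floor and not an exact figure, and the evidence behind it is thin: the limit of > 50000 nM in this assay, at which 1 of the 3 values shown sits.

The compounds shown do not tell whether the ring, its second nitrogen or the methyl group on that nitrogen accounts for the step, a question that piperidine, morpholine or a piperazine with a free amine hydrogen at this position could help to settle. From the compounds shown here alone, compound 1 also carries a piperazine ring here, but it differs from compound 3 in more than one place, so whether the same exchange would have a similar effect with another amide part remains open.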